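The source may hold more compounds than are shown below. What is called first, only, known or untested is meant among the compounds shown, and "the series" means these compounds.

- compound 1 `COc1ccc(COCNc2n[n+]([O-])c3ccccc3[n+]2[O-])cc1`: 7640 nM
- compound 2 `[O-][n+]1nc(NCOC2CCCCC2)[n+]([O-])c2ccccc21`: 5180 nM
- compound 3 `CC(C)CCOCNc1n[n+]([O-])c2ccccc2[n+]1[O-]`: not yet measured

In a functional assay on A549 cells (Homo sapiens) for cytotoxicity, read by MTT assay, with a stated time of 72 h (on this read-out higher numbers stand for weaker inhibition and lower numbers for stronger inhibition), compound 2 gives 5180 nM, which lies within the scatter of compound 1 at 7640 nM. Compound 3 differs from compound 2 at one place: isopentyl in place of cyclohexyl on an oxygen on a saturated carbon, with isopentyl in place of cyclohexyl on an oxygen on a saturated carbon. Among the measured compounds shown here, no step between measured compounds is available as a guide, and the two values show only that these two different groups give similar numbers. The expected size of the change, a 1.2-fold higher number from compound 2 to compound 3 (0.06 log units; within the scatter), is none beyond the scatter in this assay. For compound 3 the estimated value is 6000 nM, with an expected range of 2800 nM to 12500 nM.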

Compound 3, half-maximal inhibitory concentration: 7270 nM
Estimate against measurement, compound 3: 1.2-fold (0.08 log units) below; measured number inside the range.
By their numbers in this assay, from the lowest: compounds 2, 3 and 1 (each within the scatter of the next).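

In this assay, the group on the oxygen on a saturated carbon now has direct steps: isopentyl in place of cyclohexyl gives a 1.4-fold higher number from compound 2 to compound 3 (0.15 log units; within the scatter). Isobutyl in place of 4-methoxyphenyl on the saturated chain carbon bound to that oxygen gives a 1.1-fold lower number from compound 1 to compound 3 (0.02 log units; within the scatter). At this position, neither step separates a ring of carbon only or an aromatic ring from an open chain beyond the scatter.

As far as these compounds go, whether an amine, a carboxylic acid or a longer chain here would give a number beyond the scatter remains open. No other data bear on these results.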